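Swapping the nitro group of compound 1 for a larger amino acid

The source may report more compounds than this note shows. Statements on the series, on what has been measured and on what is new or still open speak of the compounds shown alone.

The series is built on a shared core whose best-studied member is compound 1 `COc1cc(OC)c(/C=C/S(=O)(=O)Nc2ccc(OC)c([N+](=O)[O-])c2)c(OC)c1`. In a functional assay on DU-145 cells (Homo sapiens) for cytotoxicity, read by trypan blue exclusion, with a stated time of 96 h (on this read-out higher numbers stand for weaker inhibition and lower numbers for stronger inhibition), compound 1 gives 2500 nM, the lowest of the three numbers shown. Compound 2 `COc1ccc(NS(=O)(=O)/C=C/c2c(OC)cc(OCCCC(=O)O)cc2OC)cc1[N+](=O)[O-]` carries a 2-carboxyethyl chain on the core and gives 100000 nM in this assay, so that the change from a 40-fold higher number from compound 1 to compound 2 (1.60 log units; beyond the scatter). Compound 3 `COc1cc(OC)c(/C=C/S(=O)(=O)Nc2ccc(F)c([N+](=O)[O-])c2)c(OC)c1` has fluoro in place of methoxy and gives 100000 nM, so that the change from a 40-fold higher number from compound 1 to compound 3 (1.60 log units; beyond the scatter).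

Compound 4 `COc1cc(OC)c(/C=C/S(=O)(=O)Nc2ccc(OC)c(NC(C(=O)O)c3ccc(F)cc3)c2)c(OC)c1` differs from compound 1 at a single aromatic carbon: (carboxy(4-fluorophenyl)methyl)amino in place of nitro on an aromatic carbon. Going by the values given here, neither measured step touches the nitro group, so there is no direct precedent; what both show is that single changes at either end of compound 1 cost a large amount of activity. The exchange of nitro for the much larger (carboxy(4-fluorophenyl)methyl)amino group is a bigger change than either, so a large weakening is expected, and the step of a 12-fold higher number from compound 1 to compound 4 (1.08 log units; beyond the scatter) is the estimate. Compound 4 is thus expected to give about 30000 nM in this assay, with a likely range from 5000 nM to 100000 nM.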

Compound 4, half-maximal inhibitory concentration: 75 nM
For compound 4 the middle estimate is 400-fold (2.60 log units) above the measured one, outside the stated range (below it).
By their numbers in this assay, from the lowest: compound 4; then compound 1; then compounds 2 and 3 (each within the scatter of the next).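

Exchanging nitro for (carboxy(4-fluorophenyl)methyl)amino on this aromatic carbon gives a 33-fold lower number from compound 1 to compound 4 (1.52 log units; beyond the scatter) in this assay, and it is the only single change shown that lowers the number. This position therefore accepts a group of 12 heavy atoms with a six-membered aromatic ring in place of one of 3 heavy atoms, something the two earlier steps, made elsewhere on the molecule, could not reveal. Nothing at hand explains this result.

The compounds shown do not separate the contributions of the carboxylic acid, the 4-fluorophenyl ring and the amino link within the entering group. From the compounds shown here alone, whether a plain amine at this carbon, or a methyl ester in place of the carboxylic acid, would give a similar number remains open.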